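A few compounds are considered here, and "the series" means these few. Any claim that something is new, unique, unknown or untested is made for them only; others in the source may bear on it.

Working notes on the series sharing the core of compound 1 (`Cc1ccc(/C=C2/S/C(=N/c3ccccc3)N(Cc3ccncc3)C2=O)cc1`). In an ADME assay on HEK293 cells (Homo sapiens) for cytotoxicity, read by MTT assay, with a stated time of 48 h (on this read-out lower numbers stand for stronger inhibition and higher numbers for weaker inhibition), compound 1 gives 49500 nM, compound 2 (`COc1ccc(/C=C2/S/C(=N/c3ccccc3)N(Cc3ccncc3)C2=O)cc1`) gives 47900 nM and compound 3 (`CC(C)c1ccc(/C=C2/S/C(=N/c3ccccc3)N(Cc3ccncc3)C2=O)cc1`) gives 137000 nM, the highest of the three numbers.

Next in line is compound 4 (`COc1ccc(OC)c(/C=C2/S/C(=N/c3ccccc3)N(Cc3ccncc3)C2=O)c1`), which carries 2,5-dimethoxyphenyl in place of the 4-isopropylphenyl of compound 3, on a double-bonded chain carbon bound to a double-bonded ring carbon: 2,5-dimethoxyphenyl in place of 4-isopropylphenyl on a double-bonded chain carbon bound to a double-bonded ring carbon.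

Two modest measured steps end at compound 3: a 2.8-fold higher number from compound 1 to compound 3 (0.44 log units; beyond the scatter) and a 2.9-fold higher number from compound 2 to compound 3 (0.46 log units; beyond the scatter). Methoxy in place of methyl gave a 1.0-fold lower number from compound 1 to compound 2 (0.01 log units; within the scatter), within the scatter. Among the compounds with values here, no measured compound carries the 2,5-dimethoxyphenyl group, so these steps bear on the change only indirectly. Leaving the isopropyl group has so far meant a lower number, so a modest step in that direction is expected in this assay, with wide uncertainty.

The expected step is a 2.3-fold lower number from compound 3 to compound 4 (0.36 log units; beyond the scatter).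

The estimate for compound 4 is 60000 nM, with an expected range of 22000 nM to 130000 nM.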

Compound 4, half-maximal inhibitory concentration: 80100 nM
The estimate for compound 4 lay 1.3-fold (0.13 log units) below the measured number; measured number inside the range.
By their numbers in this assay, from the lowest: compounds 2, 1, 4 and 3 (each within the scatter of the next, the first and the last beyond it).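

In this assay the 2,5-dimethoxyphenyl group at this place, on a double-bonded chain carbon bound to a double-bonded ring carbon, cannot be told apart from any of the three earlier aryl groups: the steps are a 1.7-fold lower number from compound 3 to compound 4 (0.23 log units; within the scatter) and a 1.7-fold higher number from compound 2 to compound 4 (0.22 log units; within the scatter) and a 1.6-fold higher number from compound 1 to compound 4 (0.21 log units; within the scatter) as read against each earlier compound. Compound 4 therefore sits within the scatter of all three, and the two hydrogen-bond acceptors that enter with the change bring no step beyond it, while the only gaps beyond the scatter remain those that set compound 3 apart from compound 1 and compound 2. No measured evidence offers an explanation for this result.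

The compounds shown leave open which methoxy group of compound 4, if either, affects the number. They also leave open whether an amine or a carboxylic acid on the aryl ring at this place would give a step beyond the scatter.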